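The source may hold more compounds than are shown below. What is called first, only, known or untested is meant among the compounds shown, and "the series" means these compounds.

Measured compounds:
Compound 1 `CCCCCC(=O)Nc1cc2nc(C3CCCCC3)[nH]c2cc1N1CCCC1` gives > 100 ug/mL in an ADME assay on Vero cells (Chlorocebus sabaeus) for cytotoxicity, read by resazurin assay, with a stated time of 3 days; a higher number here means a weaker inhibitor, a lower number a stronger inhibitor.
Compound 2 `COCCOC(=O)Nc1cc2nc(C3CCCCC3)[nH]c2cc1N1CCCC1` gives > 100 ug/mL in this assay.

Both values are limits of this assay, not numbers. Compound 2 therefore stands only at a limit in this assay, with no measured number to place it. Among the measured compounds shown here, the one step between measured compounds, a step that the two limits leave unreadable from compound 1 to compound 2, cannot be read in size because of the limit of > 100 ug/mL in this assay, at which 2 of the 2 values shown sit; it tells only that the exchange of the pentyl for a 2-methoxyethoxy on the carbonyl carbon did not bring the value below the limit.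

Compound 3 `CCCCNC(=O)Nc1cc2nc(C3CCCCC3)[nH]c2cc1N1CCCC1` is not yet measured. It differs from compound 2 by butylamino in place of 2-methoxyethoxy on a carbonyl carbon. For the measured compounds named here, no measured step bears directly on this exchange; the only step available, from compound 1 to compound 2, also changes the group on the carbonyl carbon and left both ends at the limit. The expectation for this assay is therefore no step beyond the scatter, with compound 3 most likely remaining at the limit as well. The estimated step is a number no higher from compound 2 to compound 3 (the limit leaves the size open). Compound 3 is expected to give 100 ug/mL, within 50 ug/mL to 200 ug/mL.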

Compound 3, half-maximal inhibitory concentration: > 100 ug/mL
Compound 3 ended at the assay's limit (the forecaster's own chance of this, stated with the estimate: 85%); the middle value sits exactly at the limit.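

Compound 3 gives > 100 ug/mL in this assay, which is a limit and not a number. Among the compounds shown here, no step among compound 1, compound 2 and compound 3 can be read in size, because all three stand at the same limit: the limit of > 100 ug/mL in this assay, at which 3 of the 3 values shown sit. The compounds shown leave open whether pentyl, 2-methoxyethoxy and butylamino on the carbonyl carbon differ at all in this assay.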